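A Polar Aryl Swap on a Six-Ring Core

This account rests on a few compounds, and the source may have more. Where it says the series, first, only, none or still open, it means among the compounds named here.

compound 1 `Cc1nc2c3ccccc3ccc2c2nc3c(ccc4ccccc43)c(-c3ccccc3Cl)c12`: 52500 nM
compound 2 `Cc1ccc(-c2c3ccc4ccccc4c3nc3c2c(C)nc2c4ccccc4ccc32)cc1`: > 80000 nM
compound 3 `Cc1nc2c3ccccc3ccc2c2nc3c(ccc4ccccc43)c(C)c12`: > 80000 nM

In a functional assay on AGS cells (Homo sapiens) for cytotoxicity, read by MTT assay, with a stated time of 48 h (a lower number here means a stronger inhibitor, a higher number a weaker inhibitor), compound 1 gives 52500 nM. Compound 2 gives only a limit, > 80000 nM. Compound 3 also gives only a limit, > 80000 nM. The set is dominated by the limit of > 80000 nM in this assay, at which 2 of the 3 values shown sit, so compound 2 stands at the weak end of what this assay can report.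

Compound 4 `Cc1nc2c3ccccc3ccc2c2nc3c(ccc4ccccc43)c(-c3nccnc3N)c12` differs from compound 2 by 3-aminopyrazin-2-yl in place of 4-methylphenyl on an aromatic carbon. The measured steps at this position are an at least 1.5-fold higher number from compound 1 to compound 2 (0.18 log units; that floor lies within the scatter) and a step that the two limits leave unreadable from compound 2 to compound 3; neither introduces a 3-aminopyrazin-2-yl, so none bears directly on the change. With every neighbour weak, no step beyond the scatter is expected in either direction. Compound 4 is therefore expected near 70000 nM, between 25000 nM and 200000 nM. That estimate means an expected step of an at least 1.1-fold lower number from compound 2 to compound 4 (0.05 log units; that floor lies within the scatter).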

Compound 4, half-maximal inhibitory concentration: 2260 nM
For compound 4 the middle estimate is 31-fold (1.49 log units) above the measured one, and the stated range ends above it.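

The position opposite the ring nitrogen is far from indifferent in this assay: with 3-aminopyrazin-2-yl in place of 4-methylphenyl there is an at least 35-fold lower number from compound 2 to compound 4 (1.54 log units; beyond the scatter), and in place of methyl there is an at least 35-fold lower number from compound 3 to compound 4 (1.54 log units; beyond the scatter). Even against 2-chlorophenyl, the one earlier group with a true number, the change gives a 23-fold lower number from compound 1 to compound 4 (1.37 log units; beyond the scatter). The first two steps are only floors, because each starts from a limit: the limit of > 80000 nM in this assay, at which 2 of the 4 values shown sit.

Which part of the new group matters remains open. Whether 2-aminophenyl, which keeps the amine, or pyrazin-2-yl, which keeps the ring without it, would give the same gain cannot be told from these compounds.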